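Dimethylamino for amino at the five-membered ring carbon

This account rests on a few compounds, and the source may have more. Where it says the series, first, only, none or still open, it means among the compounds named here.

Measured compounds:
compound 1 `Nc1nc2c(nc(I)n2COCCO)c(=O)[nH]1` gives >= 350 ug/mL in a functional assay (Oryctolagus cuniculus) for inhibition (a higher number here means a weaker inhibitor, a lower number a stronger inhibitor), a limit of the assay and not a number
compound 2 `Nc1nc2c(nc(O)n2COCCO)c(=O)[nH]1` gives 48 ug/mL
compound 3 `Nc1nc2c(nc(N)n2COCCO)c(=O)[nH]1` gives 290 ug/mL

Compound 3 has the highest of the two numbers; its nearest neighbour is compound 2, with a 6.0-fold higher number from compound 2 to compound 3 (0.78 log units; beyond the scatter). The substituent on this aromatic carbon matters, as an at least 7.2-fold lower number from compound 1 to compound 2 (0.86 log units; beyond the scatter) also shows. Compound 4 `CN(C)c1nc2c(=O)[nH]c(N)nc2n1COCCO` carries dimethylamino in place of amino on an aromatic carbon. Among the measured compounds shown here, no measured step involves dimethylamino, so the direction is open; the steps at this position range from within the scatter an at least 1.2-fold lower number from compound 1 to compound 3 (0.08 log units; that floor lies within the scatter) to modest. For compound 4 in this assay a small step is expected, a 1.1-fold higher number from compound 3 to compound 4 (0.04 log units; within the scatter), and the estimate is 320 ug/mL with a range from 120 ug/mL to 900 ug/mL, with a real chance of a limit like (the limit of >= 350 ug/mL in this assay, at which 1 of the 3 values shown sits).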

Compound 4, concentration for 50% inhibition: > 400 ug/mL
Compound 4 gave a limit, no number; the forecaster's own chance of this, stated with the estimate: 40%; at least 1.2-fold (0.09 log units) between middle value and limit.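

In this assay compound 4 gives only a limit, > 400 ug/mL. Dimethylamino in place of amino gives an at least 1.3-fold higher number from compound 3 to compound 4 (0.13 log units; that floor lies within the scatter), so this step shows no change, whereas dimethylamino in place of hydroxy gives an at least 8.3-fold higher number from compound 2 to compound 4 (0.92 log units; beyond the scatter). Compound 2 thus remains the strongest inhibitor of the four, and the step from the iodo compound cannot be read since both values are limits.

Still open, as far as these compounds go, is whether methylamino, which lies between amino and dimethylamino, or methoxy at this carbon would come close to hydroxy.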